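Trimming the linker to a short alkyne on the core

The source may report more compounds than this note shows. Statements on the series, on what has been measured and on what is new or still open speak of the compounds shown alone.

Compound 1 `Cc1ncsc1-c1ccc(CNC(=O)[C@@H]2C[C@@H](O)CN2C(=O)[C@@H](NC(=O)COCCOCCOc2ccc(Cl)cc2C(=O)Nc2ccc([N+](=O)[O-])cc2Cl)C(C)(C)C)cc1`: 2340 nM
Compound 2 `Cc1ncsc1-c1ccc(CNC(=O)[C@@H]2C[C@@H](O)CN2C(=O)[C@@H](NC(=O)COCCOCCn2cc(CCOc3ccc(Cl)cc3C(=O)Nc3ccc([N+](=O)[O-])cc3Cl)nn2)C(C)(C)C)cc1`: 2790 nM
Compound 3 `O=C(O)COCCOCCOc1ccc(Cl)cc1C(=O)Nc1ccc([N+](=O)[O-])cc1Cl`: > 10000 nM

In a functional assay on PC-3 cells (Homo sapiens) for inhibition, read by WST assay, with a stated time of 3 days (on this read-out higher numbers stand for weaker inhibition and lower numbers for stronger inhibition), compound 1 gives 2340 nM and compound 2 gives 2790 nM. Compound 3 stands apart: its result in this assay is only a limit of the assay, > 10000 nM, not a number, and it sits at the limit of > 10000 nM in this assay, at which 1 of the 3 values shown sits. Compound 4 `C#CCCOc1ccc(Cl)cc1C(=O)Nc1ccc([N+](=O)[O-])cc1Cl` keeps the core of compound 3 but carries ethynyl in place of 2-(carboxymethoxy)ethoxy on a saturated chain carbon, two bonds along the chain from an oxygen on an aromatic ring. Since compound 3 already reaches the limit, no step beyond the scatter is expected for the move a step that the limit leaves unreadable from compound 3 to compound 4. Compound 4 is therefore estimated at 15000 nM, within 4000 nM to 60000 nM.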

Compound 4, half-maximal inhibitory concentration: > 10000 nM
Compound 4: only a limit was reported; the forecaster's own chance of this, stated with the estimate: 70%; the middle value does not contradict the limit.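

For the compounds shown here, compound 4, like compound 3, gives only a limit of the assay, so no step between them can be read: the limit of > 10000 nM in this assay, at which 2 of the 4 values shown sit. Going by these compounds, whether ethynyl in place of 2-(carboxymethoxy)ethoxy changes inhibition at all stays open.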